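The source may hold more compounds than are shown below. What is called first, only, known or untested is meant among the compounds shown, and "the series" means these compounds.

Measured so far:
- compound 1, `Cn1cnc2c(Sc3ccccc3)ncnc21`: 8%
- compound 2, `Cn1c(-c2ccccc2)nc2c(Sc3ccccc3)ncnc21`: 1%

Both values come from an assay on isolated protein for inhibition of Ca2+/calmodulin-dependent protein kinase II (CaM kinase II) (Rattus norvegicus), tested at 30 uM; on this read-out higher numbers stand for more inhibition at the one concentration tested (going by the name of the read-out) and lower numbers for less inhibition. In this assay compound 1 gives 8% and compound 2 gives 1%; the two numbers lie within the usual scatter of each other, so neither compound can be said to inhibit more than the other, and both sit near the bottom of the scale. Among the measured compounds shown here, the one measured step, a number 7 percentage points lower from compound 1 to compound 2 (within the scatter), is the replacement of hydrogen by phenyl on an aromatic carbon of the shared core.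

Compound 3, `CSc1ccc(-c2nc3c(Sc4ccccc4)ncnc3n2C)cc1`, has not yet been measured. It differs from compound 2 in one place: methylsulfanyl in place of hydrogen on an aromatic carbon. For the measured compounds named here, no measured pair shows what adding a group to this phenyl does. Going by the values given here, the only step at hand, a number 7 percentage points lower from compound 1 to compound 2 (within the scatter), shows that a much larger change, the whole phenyl itself, moved the number by less than the scatter. Among the compounds with values here, with both measured compounds low and the sole step flat, the expected step of a number 2 percentage points higher from compound 2 to compound 3 (within the scatter) is none beyond the scatter. Compound 3 is therefore estimated at 3%, with a range from -8% to 15%.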

Compound 3, a percentage reported as inhibition, at one concentration (the size of the read-out at that concentration, not a potency): 0%
For compound 3 the middle estimate is 3 percentage points above the measured one, and the stated range covers the measured number.
By their numbers in this assay, from the lowest: compounds 3, 2 and 1 (each within the scatter of the next).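

In this assay, methylsulfanyl in place of hydrogen on an aromatic carbon, para to a large group, gives a number 1 percentage points lower from compound 2 to compound 3 (within the scatter), so the first group placed on the phenyl ring makes no difference that can be told apart from the scatter. Measured against the core of compound 1, which carries only hydrogen at this carbon, the whole 4-(methylsulfanyl)phenyl gives a number 8 percentage points lower from compound 1 to compound 3 (within the scatter), so even the ring and its added group together do not move the number beyond the scatter. Nothing measured here bears on why these numbers stay so close together.

The compounds shown hold only one group at one place on this phenyl ring, so it remains open whether an amine or a carboxylic acid there would raise inhibition beyond the scatter. With all three numbers near the bottom of the scale, a change that lowers inhibition would be hard to detect, so these compounds can reveal only a group that raises it, and methylsulfanyl is not such a group in this series.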